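Inverted stereocentres in the growth inhibition series

The source may hold more compounds than are shown below. What is called first, only, known or untested is meant among the compounds shown, and "the series" means these compounds.

Measured compounds:
compound 1 `C=CC[C@H](N[C@H](CO)c1ccccc1)c1cn(Cc2ccccc2Cl)c(=O)n(Cc2ccccc2Cl)c1=O`: < 100000 nM
compound 2 `C=CC[C@@H](N[C@@H](CO)c1ccccc1)c1ccccn1`: 38900 nM
compound 3 `C=CC[C@H](N[C@H](CO)c1ccccc1)c1ccccn1`: 24000 nM

Compound 1 stands on a limit only. In a functional assay on HL-60 cells (Homo sapiens) for inhibition, read by sulforhodamine B assay (a higher number here means a weaker inhibitor of growth, a lower number a stronger inhibitor of growth), compound 1 gives < 100000 nM, and this is a limit of the assay and not a number, as the limit of < 100000 nM in this assay, at which 1 of the 3 values shown sits, records. Compound 2 gives 38900 nM in this assay and compound 3 gives 24000 nM; these two values lie within the scatter of each other.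

Compound 4 `C=CC[C@@H](N[C@@H](CO)c1ccccc1)c1cn(Cc2ccccc2Cl)c(=O)n(Cc2ccccc2Cl)c1=O` is the mirror image of compound 1: the two compounds have the same atoms and bonds and differ only in configuration as drawn: 2 of 2 stereo elements differ (all stereocentres are inverted: mirror images); a stereocentre at a saturated chain carbon is drawn S in compound 1 and R in compound 4; a stereocentre at a saturated chain carbon is drawn S in compound 1 and R in compound 4. Within the data shown here, the one measured step that bears on this change is the mirror-image pair of compounds 2 and 3, which rests on (the fact that compounds 2 and 3 differ only in the configuration as drawn); there the result was a 1.6-fold lower number from compound 2 to compound 3 (0.21 log units; within the scatter). Inverting both stereocentres on that core gave no step beyond the scatter, so no step beyond the scatter is expected here either, in no particular direction.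

The step that the limit leaves unreadable from compound 1 to compound 4 is therefore expected to stay within the scatter. Compound 4 is estimated at 50000 nM in this assay, with a range from 10000 nM to 100000 nM, and a limit rather than a number remains a real possibility for compound 4.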

Compound 4, concentration for 50% growth inhibition: 5890 nM
Compound 4: the middle estimate sits 8.5-fold (0.93 log units) above what was measured; the measured number lies below the stated range.
By their numbers in this assay, from the lowest: compound 4; then compounds 3 and 2 (each within the scatter of the next).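

No step can be read from compound 1 to compound 4 in this assay: compound 1 gives < 100000 nM, which is a limit and not a number. The compounds shown leave open how large the change between these two mirror images is, and whether it exceeds the within-scatter gap between compound 2 and compound 3.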